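The source may report more compounds than this note shows. Statements on the series, on what has been measured and on what is new or still open speak of the compounds shown alone.

Working notes on the series. The three measured compounds share one core and differ at the amide nitrogen and on the ring. In a toxicity assay on the whole organism (strain Icem-CET (SPF Caw)) for cytotoxicity, with Mus musculus as the target (on this read-out higher numbers stand for an effect only at larger amounts of compound and lower numbers for an effect already at smaller amounts), compound 1 `C=CCNC(=O)/C(C)=C(\C)c1ccc(Br)cc1` gives 500 mg/kg. In this assay compound 2 `C#CCNC(=O)/C(C)=C(\C)c1ccccc1` gives 400 mg/kg. In this assay compound 3 `C/C(C(=O)NC1CC1)=C(/C)c1ccccc1` gives 250 mg/kg. For the measured compounds named here, compound 3 thus carries the lowest of the three numbers, but the gaps to both neighbours stay within the scatter: the only single-change step, a 1.6-fold lower number from compound 2 to compound 3 (0.20 log units; within the scatter), and compound 1 sits only a little higher than compound 2.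

Compound 4 `C/C(C(=O)NC1CC1)=C(/C)c1ccc(C)cc1` is the next compound, differing from compound 3 by methyl in place of hydrogen on an aromatic carbon. Going by the values given here, no measured step bears on this change: compound 1 and compound 2 differ both on the ring and at the amide nitrogen, so their two values show nothing separate about a ring substituent, and no other pair touches the ring at all. Among the compounds with values here, with no step pointing either way, the expectation for compound 4 in this assay is no step beyond the scatter, that is no change at the digits printed from compound 3 to compound 4 (within the scatter). Compound 4 is therefore estimated at 250 mg/kg, with a range from 125 mg/kg to 500 mg/kg.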

Compound 4, dose for half-maximal effect: 300 mg/kg
Compound 4: middle estimate off by 1.2-fold (0.08 log units), on the low side; measured number inside the range.
By their numbers in this assay, from the lowest: compounds 3, 4, 2 and 1 (each within the scatter of the next).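

In this assay, the ring position para to a large group now has its first single-change reading: methyl in place of hydrogen on an aromatic carbon, with the cyclopropyl group kept on the amide nitrogen, gives a 1.2-fold higher number from compound 3 to compound 4 (0.08 log units; within the scatter). Until now, the only listed step concerned the amide nitrogen, so this is the first sign that a substituent at this ring position can be added without moving the read-out beyond the scatter, although it covers methyl alone on this one background. No accompanying measurement bears on this result.

Still open, going by these compounds, is whether a group other than methyl at this position, such as bromine, a methoxy group, a carboxylic acid, an amine or a longer chain, would also stay within the scatter on the cyclopropyl amide; the bromine of compound 1 cannot answer this, since compound 1 also carries a different group on the amide nitrogen. Also open, on these data alone, is whether methyl at this position would give a similar step with propargyl on the amide nitrogen, and whether other ring positions would behave alike.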